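The compounds below may be only part of what the source reports. "The series", "measured", "known", "first", "only" and "open" are said of these compounds alone.

Compound 2 `Cc1ccc(N2CCC(C)(O)CC2)nc1C(=O)Nc1c(C)cc(C(=O)O)cc1C` stands highest of the two numbers in a functional assay on HEK293 cells for antagonist activity at prostaglandin E2 receptor EP4 subtype (Homo sapiens), read by HTRF and cAMP accumulation, with a stated time of 20 min (a higher number here means a weaker inhibitor, a lower number a stronger inhibitor), giving 39.8 nM, while compound 1 `Cc1ccc(N2CCC(F)(F)CC2)nc1C(=O)Nc1c(C)cc(C(=O)O)cc1C` gives 1.61 nM in this assay. For the measured compounds named here, the one measured step, a 25-fold higher number from compound 1 to compound 2 (1.39 log units; beyond the scatter), shows that a change at this place can move the number far. Compound 3 `COC1CCN(c2ccc(C)c(C(=O)Nc3c(C)cc(C(=O)O)cc3C)n2)CC1` differs from compound 2 by 4-methoxypiperidin-1-yl in place of 4-hydroxy-4-methylpiperidin-1-yl on an aromatic carbon. Going by the values given here, no measured step matches this exchange, so the direction rests only on the large step already seen at this place. The step is expected to be a 2.7-fold lower number from compound 2 to compound 3 (0.42 log units; beyond the scatter). Compound 3 is thus expected to give 15 nM, within a range from 4 nM to 60 nM.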

Compound 3, half-maximal inhibitory concentration: 96.7 nM
The estimate for compound 3 lay 6.4-fold (0.81 log units) below the measured number, and the stated range ends below it.
By their numbers in this assay, from the lowest: compound 1; then compound 2; then compound 3.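

Exchanging 4-hydroxy-4-methylpiperidin-1-yl for 4-methoxypiperidin-1-yl, with the same atoms but no hydrogen-bond donor, gave a 2.4-fold higher number from compound 2 to compound 3 (0.39 log units; beyond the scatter) in this assay and so did not move the number back toward compound 1. Measured against 4,4-difluoropiperidin-1-yl, the step is wider still, a 60-fold higher number from compound 1 to compound 3 (1.78 log units; beyond the scatter), so both oxygen-bearing groups lie far on the weaker side of compound 1. No measurement offered here explains this order. 
Because the hydroxyl and the methyl both shift in this exchange, the compounds shown cannot separate their contributions. As far as these compounds go, whether a plain piperidine, a 4-fluoropiperidine or an amine at this place would stand nearer compound 1 remains open.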